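Swapping the bicyclic group on the urea nitrogen

The source may hold more compounds than are shown below. What is called first, only, known or untested is meant among the compounds shown, and "the series" means these compounds.

Of the compounds shown here, three have been measured in an assay on isolated protein for antagonist activity at transient receptor potential cation channel subfamily V member 1 (Homo sapiens), read by FLIPR; on this read-out lower numbers stand for stronger inhibition and higher numbers for weaker inhibition. Compound 1, `CC(C)(C)c1ccc(CNC(=O)Nc2cccc3cnccc23)cc1`, gives 13.8 nM. Compound 2, `CC1CCN(c2nc(C(F)(F)F)ccc2CNC(=O)Nc2ccc3ccccc3n2)CC1`, built on the same left-hand part as the compounds that follow, gives "not active" (no number reported) in this assay. Compound 3, `CC1CCN(c2nc(C(F)(F)F)ccc2CNC(=O)Nc2ccc3cnncc3c2)CC1`, gives 8.9 nM in this assay. Compound 3 and compound 1 therefore lie within the usual scatter of each other, so neither can be called the stronger of the two, while compound 2 stands apart without a number.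

Compound 4, `CC1CCN(c2nc(C(F)(F)F)ccc2CNC(=O)Nc2cncc3ccccc23)CC1`, is the next step. It keeps the whole left-hand part of compound 3 and differs only in the bicyclic group on the urea: a group of 10 heavy atoms (9 carbon, 1 nitrogen; one six-membered aromatic ring of carbon only, one six-membered aromatic ring with 1 hetero atom) in place of a group of 10 heavy atoms (8 carbon, 2 nitrogen; one six-membered aromatic ring of carbon only, one six-membered aromatic ring with 2 hetero atoms), on an amide-type nitrogen.

Within the data shown here, no measured pair covers this exchange, so the expected size of the step is uncertain. Compound 2 shows that a change of the bicyclic group on this nitrogen can remove activity altogether, whereas compound 1 shows that a different bicyclic group on a different left-hand part still gives 13.8 nM. On balance the step from compound 3 to compound 4 is estimated as small, a 2.2-fold higher number from compound 3 to compound 4 (0.35 log units; beyond the scatter), and not clearly beyond the scatter. Compound 4 is thus expected to give about 20 nM in this assay, somewhere between 5 nM and 80 nM.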

Compound 4, inhibition constant: 1.8 nM
The estimate for compound 4 lay 11-fold (1.05 log units) above the measured number; the measured number lies below the stated range.
By their numbers in this assay, from the lowest: compound 4; then compounds 3 and 1 (each within the scatter of the next).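

Among these compounds, this is the first step measured directly at this position with the left-hand part held fixed: placing isoquinolin-4-yl on the amide-type nitrogen gives a 4.9-fold lower number from compound 3 to compound 4 (0.69 log units; beyond the scatter) in this assay, a change beyond the usual scatter towards stronger inhibition. It also sharpens what compound 2 hinted at, since compound 2, with the same left-hand part, gives "not active" (no number reported), while compound 4 gives 1.8 nM, so the bicyclic group on this nitrogen alone can separate a compound without a reported number from one with a low number. The compounds shown offer no separate measurement that would explain why this exchange lowers the number.

A single step cannot show how the result depends on the number of ring nitrogens or on where they sit, so a naphthalen-1-yl group, built of carbon only, on the same nitrogen would be an informative comparison. As far as these compounds go, it also remains open whether isoquinolin-4-yl would give a similarly low number on the different left-hand part of compound 1.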